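The source may report more compounds than this note shows. Statements on the series, on what has been measured and on what is new or still open speak of the compounds shown alone.

Compound 1 `CN(C(=O)NC(=O)c1ccc(C(F)(F)F)cc1)c1nc(C(F)(F)F)c(C(=O)N/N=C/c2ccc(C(F)(F)F)cc2)s1` gives in a functional assay on A549 cells (Homo sapiens) for inhibition, read by MTT assay, with a stated time of 72 h (on this read-out higher numbers stand for weaker inhibition and lower numbers for stronger inhibition), only a limit, > 100 ug/mL.
Compound 2 `CN(C(=O)NC(=O)c1ccc(F)c(F)c1)c1nc(C(F)(F)F)c(C(=O)N/N=C/c2cccc(C(F)(F)F)c2)s1` gives in this assay 6.52 ug/mL.
Compound 3 `CN(C(=O)NC(=O)c1ccc(F)c(F)c1)c1nc(C(F)(F)F)c(C(=O)N/N=C/c2cc(C(F)(F)F)cc(C(F)(F)F)c2)s1` gives in this assay 5.47 ug/mL.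

Compound 3 holds the lowest of the two numbers shown; its nearest neighbour is compound 2, and that step, a 1.2-fold lower number from compound 2 to compound 3 (0.08 log units; within the scatter), lies within the scatter, so the two cannot be ordered. That step, trifluoromethyl in place of hydrogen on an aromatic carbon, is the only measured one, and it concerns a different part of the molecule. Compound 4 `CN(C(=O)NC(=O)c1ccc(C(F)(F)F)cc1)c1nc(C(F)(F)F)c(C(=O)N/N=C/c2cc(C(F)(F)F)cc(C(F)(F)F)c2)s1` differs from compound 3 by 4-(trifluoromethyl)phenyl in place of 3,4-difluorophenyl on a carbonyl carbon. Among the compounds with values here, no measured pair differs in that place alone, so no step bears on it directly. Compound 1 carries the same 4-(trifluoromethyl)phenyl on the carbonyl and gave only a limit, (the limit of > 100 ug/mL in this assay, at which 1 of the 3 values shown sits). Compound 2 and compound 3 carry 3,4-difluorophenyl there and both gave numbers, though compound 1 and compound 2 differ in two places. For compound 4 a higher number than for compound 3 is therefore expected, a step of a 4.6-fold higher number from compound 3 to compound 4 (0.66 log units; beyond the scatter). Compound 4 is estimated at 25 ug/mL, in a range from 6 ug/mL to 100 ug/mL, with a real chance that only a limit is reported.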

Compound 4, half-maximal inhibitory concentration: 5.9 ug/mL
Compound 4: the middle estimate sits 4.2-fold (0.63 log units) above what was measured, and the stated range ends above it.
By their numbers in this assay, from the lowest: compounds 3, 4 and 2 (each within the scatter of the next). At a limit, above all of these: compound 1.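

On the carbonyl carbon whose other neighbour is an amide-type nitrogen, replacing 3,4-difluorophenyl with 4-(trifluoromethyl)phenyl gives in this assay a result of a 1.1-fold higher number from compound 3 to compound 4 (0.03 log units; within the scatter) and so leaves the reading unchanged as far as this assay can tell. Within the data shown here, this is the first direct comparison at this position, and it shows that, alongside the other aromatic ring of compound 3, the position accepts either group. Compound 1 carries the same 4-(trifluoromethyl)phenyl but gives only a limit: the limit of > 100 ug/mL in this assay, at which 1 of the 4 values shown sits.

So that group does not by itself rule out a measurable number, and the compounds shown leave open whether the swap would read the same with the other aromatic ring of compound 1 or compound 2. Also open, on these data alone, is how this position would respond to a group of a different kind, such as a phenyl carrying a carboxylic acid or an amine.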